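Swapping a Ring Carbon for Oxygen in a Cyclohexyl Amide

The source may hold more compounds than are shown below. What is called first, only, known or untested is meant among the compounds shown, and "the series" means these compounds.

Of the compounds shown here, three have been measured in an ADME assay on microsomes (Rattus norvegicus) for metabolic stability; on this read-out lower numbers stand for a shorter-lived compound and higher numbers for a longer-lived compound. Compound 1 `O=C(C1CCCCC1)N1N=CCC1c1ccccc1` carries a cyclohexyl on its carbonyl carbon and gives 0.0833 h in this assay. Compound 2 `CC(C)(C)C(=O)N1N=CCC1c1cccc(Cl)c1` gives 0.05 h, and compound 3 `CC(C)(C)C(=O)N1CCSC1c1ccccc1` gives 0.0533 h. Compound 1 sits at the top of the three numbers as written, but its gaps to compound 3 and to compound 2 both lie within the usual scatter of repeated measurements, so the three cannot be told apart on this evidence; all of them are short-lived.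

The next compound, compound 4 `O=C(C1CCOCC1)N1N=CCC1c1ccccc1`, differs from compound 1 in a single place: oxan-4-yl in place of cyclohexyl on a carbonyl carbon. Within the data shown here, no pair of measured compounds shows this kind of exchange, so there is no measured step to lean on. With the three measured values so close together and nothing pointing in either direction, the expectation is a step from compound 1 to compound 4 of a 1.2-fold higher number from compound 1 to compound 4 (0.08 log units; within the scatter), that is, none beyond the scatter. Compound 4 is therefore estimated to give 0.1 h in this assay, somewhere between 0.04 h and 0.25 h.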

Compound 4, half-life: > 1.5 h
Compound 4 was reported as a limit; the forecaster's own chance of this, stated with the estimate: 5%; at least 15-fold (1.17 log units) between middle value and limit.
By their numbers in this assay, from the lowest: compounds 2, 3 and 1 (each within the scatter of the next). At a limit, above all of these: compound 4.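

At this place, on a carbonyl carbon whose other neighbour is an amide-type nitrogen in a ring, oxan-4-yl in place of cyclohexyl gives an at least 18-fold higher number from compound 1 to compound 4 (1.25 log units; beyond the scatter). In this assay, compound 4 gives > 1.5 h, which is a limit of the assay and not a number: the limit of > 1.5 h in this assay, at which 1 of the 4 values shown sits. Among these compounds, until now no measured step had touched this place, and this one shows that a single ring oxygen, with the count of heavy atoms unchanged, can turn a short-lived compound into a far longer-lived one.

As far as these compounds go, this rests on one pair on one core, so it remains open whether the exchange would do the same on another core. From the compounds shown here alone, it is also open whether the gain is specific to oxygen or would also come with a ring nitrogen, as in piperidin-4-yl, or a ring sulfur, as in thian-4-yl.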